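A sulfonyl swap from compound 2 to compound 3

The source may hold more compounds than are shown below. What is called first, only, known or untested is meant among the compounds shown, and "the series" means these compounds.

In an ADME assay on microsomes from liver (Homo sapiens) for metabolic stability, read by LC-MS, with a stated time of 40 min, tested at 0.5 uM (a lower number here means slower removal, a higher number faster removal of the compound), two compounds have been measured. Compound 1 `O=C(Nc1cccc(S(=O)(=O)C2CCCC2)c1)c1cccnc1N1CCC(F)(F)CC1` reads > 399 mL.min-1.g-1 and that figure is a limit of the assay, not a number. Among the compounds with values here, compound 2 `CC(C)(CO)S(=O)(=O)c1cccc(NC(=O)c2cccnc2N2CCC3(CC2)CC3)c1` gives 154 mL.min-1.g-1 as the only actual number so far. Compound 3 `O=C(Nc1cccc(S(=O)(=O)C2COC2)c1)c1cccnc1N1CCC2(CC1)CC2` has not been measured. It carries oxetan-3-yl in place of 1-(hydroxymethyl)-1-methylethyl on a sulfonyl sulfur and keeps the rest of compound 2. Within the data shown here, no measured step bears on this change, so the expectation rests on compound 2 alone, at 154 mL.min-1.g-1 as its starting point. In this assay an estimated step of a 1.2-fold higher number from compound 2 to compound 3 (0.07 log units; within the scatter) is expected, leaning slightly towards faster removal and staying within the usual scatter. The estimated value for compound 3 is 180 mL.min-1.g-1 with an expected range of 80 mL.min-1.g-1 to 390 mL.min-1.g-1 as its likely span.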

Compound 3, intrinsic clearance in microsomes: 183 mL.min-1.g-1
Estimate against measurement, compound 3: 1.0-fold (0.01 log units) below; the measured number falls inside the stated range.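

In this assay, within the data shown here, the swap on the sulfonyl sulfur gives a 1.2-fold higher number from compound 2 to compound 3 (0.07 log units; within the scatter), the first step that can be read at this position. An open chain carrying a hydrogen-bond donor and a four-membered ring carrying none thus give numbers that the assay does not separate, with the rest of compound 2 unchanged. Nothing measured here accounts for this result.

Compound 1 reads > 399 mL.min-1.g-1, a limit of the assay and not a number, and steps to it cannot be read. From the compounds shown here alone, whether any group on the sulfonyl sulfur moves the number beyond the scatter remains open, for instance an amine such as azetidin-3-yl, a carboxylic acid or a longer chain, as does whether the oxetan-3-yl result would hold with another group in place of the spiro amine of the shared core.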